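A 2-methoxyphenyl group replaces 3-chlorophenyl in a small series

This account rests on a few compounds, and the source may have more. Where it says the series, first, only, none or still open, it means among the compounds named here.

Of the compounds shown here, three sharing one core have been measured in a functional assay on A549 cells (Homo sapiens) for inhibition, read by MTT assay, with a stated time of 24 h; on this read-out lower numbers stand for stronger inhibition and higher numbers for weaker inhibition. Compound 1 `CC1(C)[C@H]2CC[C@]1(C)N(Cc1cn(-c3ccccc3Br)nn1)C(=O)C2`, carrying 2-bromophenyl, gives 130 nM, and compound 2 `CC1(C)[C@H]2CC[C@]1(C)N(Cc1cn(-c3ccc(F)cc3)nn1)C(=O)C2`, carrying 4-fluorophenyl, gives 230 nM, with a 1.8-fold higher number from compound 1 to compound 2 (0.25 log units; within the scatter). Compound 3 `CC1(C)[C@H]2CC[C@]1(C)N(Cc1cn(-c3cccc(Cl)c3)nn1)C(=O)C2`, carrying 3-chlorophenyl, gives 60 nM, the lowest number of the three, with a 2.2-fold lower number from compound 1 to compound 3 (0.34 log units; beyond the scatter) and a 3.8-fold lower number from compound 2 to compound 3 (0.58 log units; beyond the scatter).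

Compound 4 `COc1ccccc1-n1cc(CN2C(=O)C[C@@H]3CC[C@@]2(C)C3(C)C)nn1` has not yet been measured. It has 2-methoxyphenyl in place of 3-chlorophenyl on an aromatic nitrogen. All three measured steps change the group at this same place, and none is more than modest, so a modest step is expected in this assay. The nearest comparison is the 2-bromophenyl of compound 1, and a 2.2-fold lower number from compound 1 to compound 3 (0.34 log units; beyond the scatter) suggests a change of similar size, reversed, on leaving 3-chlorophenyl. The expected change is toward a higher number, a 2.2-fold higher number from compound 3 to compound 4 (0.34 log units; beyond the scatter). For compound 4 the estimated value is 130 nM, with an expected range of 50 nM to 330 nM.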

Compound 4, half-maximal inhibitory concentration: 350 nM
The estimate for compound 4 lay 2.7-fold (0.43 log units) below the measured number; measured number outside the range, above it.
By their numbers in this assay, from the lowest: compound 3; then compounds 1, 2 and 4 (each within the scatter of the next, the first and the last beyond it).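

In this assay, 2-methoxyphenyl gives the largest step seen at this place, a 5.8-fold higher number from compound 3 to compound 4 (0.77 log units; beyond the scatter), and compound 3 now stands apart from all three other compounds, with each step to them beyond the scatter. The step from bromo to methoxy on an aromatic carbon, a 2.7-fold higher number from compound 1 to compound 4 (0.43 log units; beyond the scatter), shows that changing the group alone, with the phenyl pattern kept, is enough to move the number beyond the scatter. By contrast, a 1.5-fold higher number from compound 2 to compound 4 (0.18 log units; within the scatter) stays within the scatter, so 2-methoxyphenyl and 4-fluorophenyl cannot be told apart here.

Nothing available gives a reason for these differences. From the compounds shown here alone, whether a chlorine is needed for the low number of compound 3 stays open, as does how an amine or a carboxylic acid on the phenyl ring would read out.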